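Ethyl isoxazole styryl esters: replacing chloro by pyridin-2-yl

The source may report more compounds than this note shows. Statements on the series, on what has been measured and on what is new or still open speak of the compounds shown alone.

Compound 1 `CCOC(=O)c1cc(/C=C/c2ccccc2)on1`: "not determined" (no result reported)
Compound 2 `CCOC(=O)c1cc(/C=C/c2cccc(Cl)c2)on1`: > 128000 nM

Two compounds share the same core and differ only on the aromatic ring at the end of the vinyl chain. In an ADME assay on Vero cells (Chlorocebus sabaeus) for cytotoxicity, with a stated time of 72 h (on this read-out higher numbers stand for weaker inhibition and lower numbers for stronger inhibition), compound 1 has no result, shown as "not determined" (no result reported). In this assay compound 2 gives > 128000 nM, which is a limit of the assay and not a measured number. Compound 2 therefore stands at the limit (the limit of > 128000 nM in this assay, at which 1 of the 2 values shown sits), one of the two entries shown, and the other entry carries no single number either. Within the data shown here, no step between two measured compounds is available, so no measured change in this assay can be quoted.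

Compound 3 `CCOC(=O)c1cc(/C=C/c2cccc(-c3ccccn3)c2)on1` is the next compound. Its change from compound 2 is pyridin-2-yl in place of chloro on an aromatic carbon. Among the measured compounds shown here, with only a limit to start from, no measured step guides the expectation. The step of an at least 1.1-fold lower number from compound 2 to compound 3 (0.06 log units; that floor lies within the scatter) is expected to be none beyond the scatter, and compound 3 is estimated at 110000 nM in this assay, within a range from 30000 nM to 300000 nM.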

Compound 3, half-maximal inhibitory concentration: 113000 nM
Compound 3: the middle estimate sits 1.0-fold (0.01 log units) below what was measured; the range from low to high includes it.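

Among these compounds, compound 3 gives the first single number in this small series, with 113000 nM as its result in this assay and not a limit. At this aromatic carbon, one chlorine atom gives way to pyridin-2-yl, a group of six heavy atoms with a six-membered aromatic ring and a hydrogen-bond acceptor, and the change reads as an at least 1.1-fold lower number from compound 2 to compound 3 (0.05 log units; that floor lies within the scatter) in the same test. This large exchange therefore shows no step that can be called real, yet the true size of the step stays unknown because compound 2 sits at a limit: the limit of > 128000 nM in this assay, at which 1 of the 3 values shown sits.

The compounds shown leave open whether the ring or its nitrogen matters more for this read-out, which a plain phenyl ring at the same carbon would help to separate. They also leave open how groups of a different kind at this carbon, such as an amine or a carboxylic acid, would behave, and compound 1 has no result that could show what the unsubstituted ring does here.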